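The compounds below may be only part of what the source reports. "The series", "measured", "known", "first", "only" and "open" are said of these compounds alone.

In a functional assay on CCRF-CEM cells (Homo sapiens) for cytotoxicity, with a stated time of 72 h (a higher number here means a weaker inhibitor, a lower number a stronger inhibitor), compound 1 `Nc1nc(=O)n([C@@H]2O[C@H](CO)[C@@H](O)[C@H](O)[C@H]2O)cc1C#Cc1ccccc1` reports only a limit, > 250000 nM. Compound 2 `CCCCCc1ccc(C#Cc2cn([C@@H]3O[C@H](CO)[C@@H](O)[C@H](O)[C@H]3O)c(=O)nc2O)cc1` gives 81000 nM, and compound 3 `CCCCCc1ccc(C#Cc2cn([C@@H]3O[C@H](CO)[C@@H](O)[C@H](O)[C@H]3O)c(=O)nc2N)cc1` gives 115000 nM. Within the data shown here, compound 3 therefore stands within the scatter of compound 2, the only other compound with an exact number, as the change of amino in place of hydroxy on an aromatic carbon shows: a 1.4-fold higher number from compound 2 to compound 3 (0.15 log units; within the scatter).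

Compound 4 `CC(C)(C)c1ccc(C#Cc2cn([C@@H]3O[C@H](CO)[C@@H](O)[C@H](O)[C@H]3O)c(=O)nc2N)cc1` carries tert-butyl in place of pentyl on an aromatic carbon, (tert-butyl in place of pentyl on an aromatic carbon). Among the measured compounds shown here, the only measured step at this place is pentyl in place of hydrogen on an aromatic carbon, an at least 2.1-fold lower number from compound 1 to compound 3 (0.33 log units; beyond the scatter), and that step rests on a limit. It gives no size for exchanging one carbon group for another, so compound 4 is expected to stay close to compound 3 in this assay, with no change beyond the scatter. The expected step is a 1.1-fold higher number from compound 3 to compound 4 (0.05 log units; within the scatter). For compound 4 the estimated value is 130000 nM, with an expected range from 60000 nM to 250000 nM.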

Compound 4, half-maximal inhibitory concentration: > 250000 nM
Compound 4 ended at the assay's limit (the forecaster's own chance of this, stated with the estimate: 20%); middle value at least 1.9-fold (0.28 log units) from the limit.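

Putting tert-butyl in place of pentyl on an aromatic carbon, para to a large group, gives an at least 2.1-fold higher number from compound 3 to compound 4 (0.33 log units; beyond the scatter), so the number at this place depends on which carbon group sits there and not only on a carbon group being present. Compound 4 reports only a limit, > 250000 nM, so the step gives a minimum and not a size. The step from compound 1 to compound 4 cannot be read, as both of its ends are limits: the limit of > 250000 nM in this assay, at which 2 of the 4 values shown sit.

On these data alone, how far compound 4 lies from compound 3 remains open, as does whether the same exchange would act alike with the hydroxy group of compound 2 in place of the amino group. Also open, as far as these compounds go, is how a longer chain, an ethyl group or an amine would read at this place.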